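The source may report more compounds than this note shows. Statements on the series, on what has been measured and on what is new or still open speak of the compounds shown alone.

In an assay on OCI-Ly3 cells for activation of NF-kappa-B inhibitor alpha (Homo sapiens), read by a luciferase reporter (on this read-out higher numbers stand for an effect only at larger amounts of compound and lower numbers for an effect already at smaller amounts), compound 2 `O=[N+]([O-])c1cc(C(F)(F)F)ccc1S(=O)(=O)Nc1cccc2cccnc12` gives 3600 nM, and compound 1 `Cc1ccc2cccc(NS(=O)(=O)c3ccccc3[N+](=O)[O-])c2n1` gives 6800 nM; the two numbers lie within the usual scatter of each other, so neither stands apart. Compound 3 `Cc1ccc2cccc(NS(=O)(=O)c3ccc(C(F)(F)F)cc3[N+](=O)[O-])c2n1` differs from compound 2 by methyl in place of hydrogen on an aromatic carbon. Within the data shown here, no measured pair shows this change on its own, so the step from compound 2 to compound 3 is expected to stay within the scatter, with no clear direction, and the estimate a 1.0-fold lower number from compound 2 to compound 3 (0.01 log units; within the scatter) reflects that. Compound 3 is therefore expected to give about 3500 nM, within a range from 1200 nM to 10000 nM.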

Compound 3, half-maximal effective concentration: 10000 nM
Compound 3: the middle estimate sits 2.9-fold (0.46 log units) below what was measured; the measured number falls inside the stated range.
By their numbers in this assay, from the lowest: compounds 2, 1 and 3 (each within the scatter of the next, the first and the last beyond it).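

In this assay, methyl in place of hydrogen on the aromatic carbon next to the ring nitrogen gives a 2.8-fold higher number from compound 2 to compound 3 (0.44 log units; beyond the scatter) and is a modest step, so this position is not indifferent to even one added carbon. Trifluoromethyl in place of hydrogen on an aromatic carbon gives a 1.5-fold higher number from compound 1 to compound 3 (0.17 log units; within the scatter) and stays within the scatter, so that change shows no clear effect when the methyl is present. No supporting evidence explains the methyl step. On these data alone, whether an ethyl group or an amine at this position would shift the number further remains open.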